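A few compounds are considered here, and "the series" means these few. Any claim that something is new, unique, unknown or untested is made for them only; others in the source may bear on it.

Measured compounds in a functional assay on A549 cells (Homo sapiens) for antiproliferative activity, read by MTT assay, with a stated time of 48 h; on this read-out lower numbers stand for stronger inhibition and higher numbers for weaker inhibition:
Compound 1 `C/C(=C\CC/C(C)=C/CC[C@@H]1[C@@]2(C)CCC(=O)C(C)(C)[C@H]2CC[C@@]1(C)O)CC/C=C(\C)C(=O)OCc1cn(-c2cccc(O)c2)nn1` gives 42800 nM.
Compound 2 `C/C(=C\CC/C(C)=C/CC[C@@H]1[C@@]2(C)CCC(=O)C(C)(C)[C@H]2CC[C@@]1(C)O)CC/C=C(\C)C(=O)OCc1cn(-c2ccccc2[N+](=O)[O-])nn1` gives only a limit of the assay, > 150000 nM.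
Compound 3 `C/C(=C\CC/C(C)=C/CC[C@@H]1[C@@]2(C)CCC(=O)C(C)(C)[C@H]2CC[C@@]1(C)O)CC/C=C(\C)C(=O)OCc1cn(-c2cccc(F)c2)nn1` gives 124000 nM.

Of the two numbers, compound 3 gives the higher one; the step of a 2.9-fold higher number from compound 1 to compound 3 (0.46 log units; beyond the scatter) is beyond the scatter. Against compound 2 the step of an at least 1.2-fold lower number from compound 2 to compound 3 (0.08 log units; that floor lies within the scatter) is within the scatter.

Compound 4 `COc1ccc(-n2cc(COC(=O)/C(C)=C/CC/C(C)=C/CC/C(C)=C/CC[C@@H]3[C@@]4(C)CCC(=O)C(C)(C)[C@H]4CC[C@@]3(C)O)nn2)cc1` differs from compound 3 in one place: 4-methoxyphenyl in place of 3-fluorophenyl on an aromatic nitrogen. Among the measured compounds shown here, the steps that bear on it are a 2.9-fold higher number from compound 1 to compound 3 (0.46 log units; beyond the scatter) and an at least 3.5-fold higher number from compound 1 to compound 2 (0.54 log units; beyond the scatter), both changes of the aryl group on the triazole. Since the limit of > 150000 nM in this assay, at which 1 of the 3 values shown sits, shows that a limit may be returned, the estimate for compound 4 is uncertain; a step of a 1.2-fold lower number from compound 3 to compound 4 (0.09 log units; within the scatter) is expected, within the scatter. Compound 4 is estimated at 100000 nM, between 40000 nM and 250000 nM.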

Compound 4, half-maximal inhibitory concentration: > 150000 nM
Compound 4 gave a limit, no number (the forecaster's own chance of this, stated with the estimate: 30%); at least 1.5-fold (0.17 log units) between middle value and limit.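

In this assay, compound 4 returns only a limit, > 150000 nM. With 4-methoxyphenyl on the aromatic nitrogen, the series again reads weaker than with 3-hydroxyphenyl, an at least 3.5-fold higher number from compound 1 to compound 4 (0.54 log units; beyond the scatter), so all three replacements shown now step beyond the scatter from compound 1, whereas an at least 1.2-fold higher number from compound 3 to compound 4 (0.08 log units; that floor lies within the scatter) separates 4-methoxyphenyl from 3-fluorophenyl by no readable margin. The step between compound 2 and compound 4 cannot be read, and limits now make up much of the series: the limit of > 150000 nM in this assay, at which 2 of the 4 values shown sit.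

From the compounds shown here alone, whether the lower number of compound 1 depends on the hydroxy group itself remains open. Going by these compounds, how an amine or a carboxylic acid on the phenyl ring would read in this assay is also open.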